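The compounds below may be only part of what the source reports. "The series", "measured", "known", "first", "only" and "open" are said of these compounds alone.

Notes on the series.

Of the compounds shown here, two have been measured in an assay on CHO cells for displacement of a labelled ligand from Substance-P receptor (Homo sapiens), read by scintillation counting; a higher number here means a weaker inhibitor, a lower number a stronger inhibitor. Compound 1, `Cc1cc(F)ccc1[C@H]1C[C@@H](N2CCC2)CCN1C(=O)N(C)[C@H](C)c1cc(C(F)(F)F)cc(C(F)(F)F)c1`, gives 0.178 nM. Compound 2, `Cc1cc(F)ccc1[C@H]1C[C@@H](N2CCCC2)CCN1C(=O)N(C)Cc1cc(C(F)(F)F)cc(C(F)(F)F)c1`, gives 0.275 nM. Compound 2 stands at the higher of the two numbers, but its distance from compound 1 lies within the scatter, so the two read as equivalent. Among the measured compounds shown here, compound 1 and compound 2 differ in more than one place, so no single step can be drawn between them.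

Compound 3, `Cc1cc(F)ccc1[C@H]1C[C@@H](N2CCCC2)CCN1C(=O)N(C)[C@H](C)c1cc(C(F)(F)F)cc(C(F)(F)F)c1`, has not yet been measured. It differs from compound 2 in one place: methyl in place of hydrogen on a saturated chain carbon bound to an amide-type nitrogen and an aromatic carbon. Compound 1 already carries a methyl at that same saturated chain carbon bound to an amide-type nitrogen and an aromatic carbon, and its value sits within the scatter of compound 2, which gives no hint of a large effect from this group. The step in this assay from compound 2 to compound 3 is therefore expected to be small, at most a slight move toward a lower number, and likely not beyond the scatter; this expectation is written as a 1.4-fold lower number from compound 2 to compound 3 (0.14 log units; within the scatter). The estimate for compound 3 in this assay is 0.2 nM, within a range from 0.08 nM to 0.5 nM.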

Compound 3, inhibition constant: 0.141 nM
Compound 3: the middle estimate sits 1.4-fold (0.15 log units) above what was measured; low and high end bracket the measured number.
By their numbers in this assay, from the lowest: compounds 3, 1 and 2 (each within the scatter of the next).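

In (this assay), the methyl on the saturated chain carbon bound to an amide-type nitrogen and an aromatic carbon can now be read on its own, with the rest of the structure unchanged: the step is small (a 2.0-fold lower number from compound 2 to compound 3 (0.29 log units; within the scatter)), so hydrogen and methyl read as equivalent at this place. The saturated ring carbon can now be read on its own as well, and pyrrolidin-1-yl in place of azetidin-1-yl also gives a small step (a 1.3-fold lower number from compound 1 to compound 3 (0.10 log units; within the scatter)), so these two groups read as equivalent there, with the methyl present in both compounds. No supporting data are available to explain why either change leaves the reading within the scatter.

The compounds shown carry only hydrogen or methyl on the saturated chain carbon, so it remains open whether an ethyl group, a longer chain or the opposite configuration at that carbon would stay in the same range. From the compounds shown here alone, on the saturated ring carbon, it also remains open whether the same holds for a larger or differently built amine, such as piperidin-1-yl or morpholin-4-yl.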